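Moving the hydroxyl group on a pyridine-based cytotoxic series

A few compounds are considered here, and "the series" means these few. Any claim that something is new, unique, unknown or untested is made for them only; others in the source may bear on it.

Three compounds share one core and are compared in a functional assay on DU-145 cells (Homo sapiens) for cytotoxicity, read by CCK-8 assay and cell counting, with a stated time of 2 days; on this read-out higher numbers stand for weaker inhibition and lower numbers for stronger inhibition. Compound 1, `Oc1ccc(-c2cc(-c3ccccn3)nc(-c3ccccc3Cl)c2)cc1`, carries a pyridin-2-yl group and a 4-hydroxyphenyl group, and in this assay compound 1 gives "not determined" (no result reported). Compound 2, `Oc1cccc(-c2cc(-c3cccs3)nc(-c3ccccc3Cl)c2)c1`, pairs a thiophen-2-yl group with a 3-hydroxyphenyl group and gives 1700 nM in this assay. For the measured compounds named here, compound 3, `Oc1ccc(-c2cc(-c3ccsc3)nc(-c3ccccc3Cl)c2)cc1`, pairs a thiophen-3-yl group with a 4-hydroxyphenyl group and gives 3890 nM in this assay, the highest of the two numbers known, and its gap to compound 2 lies beyond the usual scatter.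

Compound 4, `Oc1cccc(-c2cc(-c3ccsc3)nc(-c3ccccc3Cl)c2)c1`, is built from compound 3 by one change: 3-hydroxyphenyl in place of 4-hydroxyphenyl on an aromatic carbon. The two compounds hold the same atoms joined differently. The change sits on the aromatic carbon opposite the ring nitrogen, meta to the 2-chlorophenyl group and meta to the thiophen-3-yl group.

Going by the values given here, no direct pair that differs only in this way has been measured, so the direction must be estimated from compound 2, whose 3-hydroxyphenyl group goes with the lower number, 1700 nM, though its thiophene is joined differently. A modest step toward a lower number is expected, close to the edge of the scatter, a 1.6-fold lower number from compound 3 to compound 4 (0.19 log units; within the scatter). Compound 4 is therefore estimated at 2500 nM in this assay, within 1000 nM to 6000 nM.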

Compound 4, half-maximal inhibitory concentration: 1970 nM
Compound 4: middle estimate off by 1.3-fold (0.10 log units), on the high side; low and high end bracket the measured number.
By their numbers in this assay, from the lowest: compounds 2, 4 and 3 (each within the scatter of the next, the first and the last beyond it).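

In this assay, for the compounds shown here, the first direct reading of this change, with the thiophen-3-yl group held fixed, gives a 2.0-fold lower number from compound 3 to compound 4 (0.30 log units; within the scatter) and so the hydroxyl can sit in either of these two places on the phenyl ring without a difference that stands clear of repeat-measurement noise. The second pair holds the 3-hydroxyphenyl group fixed and alters only how the thiophene is joined, giving a 1.2-fold higher number from compound 2 to compound 4 (0.06 log units; within the scatter) and showing that the two thiophene attachments cannot be told apart here either. Nothing presented here explains these results.

From the compounds shown here alone, with only these two single-change pairs, all that can be said is that neither change moves the number beyond the scatter, and whether the aromatic carbon opposite the ring nitrogen would accept a phenyl ring bearing an amine or a carboxylic acid in place of the hydroxyl remains open. The pyridin-2-yl group also stays unread, since in this assay compound 1 gives "not determined" (no result reported) and no comparison with the thiophene compounds follows from it.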